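Trifluoromethyl to Oxocyclohexylamino on a Bromoindazole Amine

A few compounds are considered here, and "the series" means these few. Any claim that something is new, unique, unknown or untested is made for them only; others in the source may bear on it.

Compound 1 `FC(F)(F)c1cccc(CNc2cc(Br)cc3[nH]ncc23)c1` and compound 2 `CC(Nc1cc(Br)cc2[nH]ncc12)c1ccc([N+](=O)[O-])cc1` share a common core and were both tested in an assay for inhibition of Indoleamine 2,3-dioxygenase 1 (Homo sapiens), with a stated time of 1 h, tested at 10 uM; on this read-out higher numbers stand for more inhibition at the one concentration tested (going by the name of the read-out) and lower numbers for less inhibition. Compound 1 gives 16% in this assay, the lowest of the two numbers shown, while compound 2 gives 17%, a number that lies within the scatter of that of compound 1, so the two cannot be separated. Compound 3 `O=C1CCCC(Nc2cccc(CNc3cc(Br)cc4[nH]ncc34)c2)C1` has not yet been measured. It differs from compound 1 in a single place: (3-oxocyclohexyl)amino in place of trifluoromethyl on an aromatic carbon. Within the data shown here, no step between measured compounds differing in one place exists here, so any expectation rests only on compound 1 with 16% and compound 2 with 17%, both low on the inhibition scale. Compound 3 is therefore expected to remain near them, with an estimated step of a number 6 percentage points higher from compound 1 to compound 3 (within the scatter) in this assay, not clearly beyond the scatter. Compound 3 is estimated at 22%, with a range from 5% to 45%.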

Compound 3, a percentage reported as inhibition, at one concentration (the size of the read-out at that concentration, not a potency): 52%
Estimate against measurement, compound 3: 30 percentage points below; measured number outside the range, above it.
By their numbers in this assay, from the lowest: compounds 1 and 2 (each within the scatter of the next); then compound 3.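

In this assay, the exchange of trifluoromethyl for (3-oxocyclohexyl)amino on this aromatic carbon, meta to a large group, gives a number 36 percentage points higher from compound 1 to compound 3 (beyond the scatter) and so shows that the number can move with a change at this position. Among these compounds, compounds 1 and 2 could not show this, as they could not be separated and offered no step between compounds differing in one place. The entering group brings more heavy atoms, a six-membered non-aromatic ring and hydrogen-bond donor and acceptors all at once, so this single step cannot be assigned to any one of these features. Nothing available explains the rise. On these data alone, whether a plain amino group or a cyclohexylamino group without the carbonyl would give a similar number remains open. So does the effect of a hydroxyl group in place of the carbonyl oxygen.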